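Replacing a methoxy group on compound 2: what to expect

A few compounds are considered here, and "the series" means these few. Any claim that something is new, unique, unknown or untested is made for them only; others in the source may bear on it.

Measured compounds:
compound 1, `CO[C@@H]1C=C(COC(C)=O)C(=O)[C@@H]2O[C@@](C)(OC)[C@](C)(OC)O[C@@H]12`: > 100000 nM
compound 2, `CO[C@H]1C=C(COC(C)=O)C(=O)[C@@H]2O[C@@](C)(OC)[C@](C)(OC)O[C@@H]12`: 62700 nM

In an assay on isolated protein for inhibition of glutathione S-transferase P (Homo sapiens), read by spectrophotometry, with a stated time of 3 min (on this read-out higher numbers stand for weaker inhibition and lower numbers for stronger inhibition), compound 1 gives > 100000 nM, which is a limit of the assay rather than a number. Going by the values given here, compound 2 gives 62700 nM in this assay, the only actual number in this set. The two compounds share every atom and bond and differ in one stereocentre; that single step is an at least 1.5-fold lower number from compound 1 to compound 2 (0.20 log units; that floor lies within the scatter).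

Compound 3, `CO[C@]1(C)O[C@H]2[C@@H](OC/C=C/c3ccccc3)C=C(COC(C)=O)C(=O)[C@@H]2O[C@@]1(C)OC`, is the next compound to be measured in this assay. Relative to compound 2 it carries 2-phenylethenyl in place of hydrogen on a saturated chain carbon bound to an oxygen on a saturated carbon, so the methoxy of compound 2 becomes a (3-phenylprop-2-en-1-yl)oxy group. Among the compounds with values here, the only measured step concerns a change of configuration and gives no guidance on adding such a group, so no direction beyond the scatter can be expected. Compound 3 is therefore estimated at 45000 nM in this assay, with a range from 8000 nM to 150000 nM. That estimate corresponds to an expected step of a 1.4-fold lower number from compound 2 to compound 3 (0.14 log units; within the scatter).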

Compound 3, half-maximal inhibitory concentration: 58000 nM
The estimate for compound 3 lay 1.3-fold (0.11 log units) below the measured number; measured number inside the range.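

In this assay, replacing the methoxy of compound 2 with a (3-phenylprop-2-en-1-yl)oxy group gives a 1.1-fold lower number from compound 2 to compound 3 (0.03 log units; within the scatter). Going by these compounds alone, the earlier pair spoke only to a change of configuration, whereas this step is the first to change the group itself: adding a 2-phenylethenyl, with its aromatic ring and double bond, leaves the number no different beyond the scatter, so this change brings neither a clear gain nor a clear loss. Nothing shown here explains why the added group makes so little difference.

Still open, from the compounds shown here alone, is whether a shorter chain such as ethyl, or an amine or a carboxylic acid at the end of the chain, would behave the same way. Going by these compounds, it is also open whether any group at this position can move the number clearly away from that of compound 2.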